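Sulfanyl to benzylamino exchange on the shared core

This account rests on a few compounds, and the source may have more. Where it says the series, first, only, none or still open, it means among the compounds named here.

Compound 1 `Nc1cc(N)c2nc(-c3ccccc3)c(Sc3ccc(F)cc3)nc2c1` is the reference point of the set. Going by the values given here, in a functional assay on SK-OV-3 cells (Homo sapiens) for inhibition, read by sulforhodamine B assay, with a stated time of 48 h (on this read-out higher numbers stand for lower toxicity in this test and lower numbers for higher toxicity in this test), compound 1 gives 63100 nM, the only value in the set that is reported as a number. Compound 2 `CCOC(=O)[C@H](CCC(=O)O)NC(=O)c1ccc(CNc2nc3cc(N)cc(N)c3nc2-c2ccccc2)cc1` is the second measured member. In this assay compound 2 returns only a limit, < 100000 nM, and not a number. Among the compounds with values here, compound 1 therefore stands as the sole numeric point, with the one other value sitting at the limit of < 100000 nM in this assay, at which 1 of the 2 values shown sits.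

Compound 3 `Nc1cc(N)c2nc(-c3ccccc3)c(NCc3ccc(F)cc3)nc2c1` has not been measured. It differs from compound 1 by (4-fluorobenzyl)amino in place of (4-fluorophenyl)sulfanyl on an aromatic carbon. Within the data shown here, no step between measured compounds that differ in one place exists in this set, so the effect of the change in this assay cannot be read from the data; the working expectation is no movement beyond the usual scatter, in either direction, with a fair chance that only a limit is returned. Compound 3 is accordingly estimated at 60000 nM, within 20000 nM to 150000 nM, which corresponds to an expected step of a 1.1-fold lower number from compound 1 to compound 3 (0.02 log units; within the scatter).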

Compound 3, concentration lethal to 50% of the cells: 53700 nM
Estimate against measurement, compound 3: 1.1-fold (0.05 log units) above, within the range that was stated.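

Going by these compounds alone, replacing (4-fluorophenyl)sulfanyl with (4-fluorobenzyl)amino gives the only readable step in this assay: a 1.2-fold lower number from compound 1 to compound 3 (0.07 log units; within the scatter). At this position, on an aromatic carbon next to the ring nitrogen and ortho to a phenyl group, the read-out therefore does not separate the sulfur-linked aryl group from the nitrogen-linked benzyl group, although the entering group adds a hydrogen-bond donor and the linker changes in both its atoms and its length. Compound 2 returns only a limit and not a number, so no step to it can be read: the limit of < 100000 nM in this assay, at which 1 of the 3 values shown sits.

As far as these compounds go, whether this insensitivity extends to groups without an aromatic ring at the same position, such as a plain amine, a morpholine or a longer alkyl chain, remains open, as does the effect of a carboxylic acid or a chlorine on the benzyl ring in place of the fluorine. With a single step, the series also cannot show whether the sulfur and nitrogen linkers would behave alike with other aryl groups attached.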